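The compounds below may be only part of what the source reports. "The series", "measured", "known", "first", "only" and "open" are said of these compounds alone.

Compound 1 `CC(C)N1C(=O)NC2(CC2c2ccc3cccc(OCc4ccccc4)c3n2)C1=O` is the starting point of this comparison. Among the measured compounds shown here, in a functional assay on the whole organism (strain Kunming) with Mus musculus as the target, with a stated time of 0.5 h (a lower number here means that less compound is needed, a higher number that more compound is needed for the effect), compound 1 gives 100 mg/kg, which is the lowest of the two numbers measured so far. For the measured compounds named here, its only measured companion is compound 2 `O=C1NC2(CC2c2ccc3cccc(OCc4ccccc4)c3n2)C(=O)N1C1CCCCC1`, and in this assay compound 2 gives 300 mg/kg. Going by the values given here, the single measured step, a 3.0-fold higher number from compound 1 to compound 2 (0.48 log units; beyond the scatter), came from cyclohexyl in place of isopropyl on an amide-type nitrogen in a ring.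

Compound 3 `O=C1NC2(CC2c2ccc3cccc(OCc4ccccc4)c3n2)C(=O)N1c1ccc([N+](=O)[O-])cc1` has not yet been measured. Its difference from compound 1 is this: 4-nitrophenyl in place of isopropyl on an amide-type nitrogen in a ring. The step from compound 1 to compound 2 is the only one that bears on this change, since it also replaced isopropyl at the same amide-type nitrogen in a ring, and it moved the number up by a modest amount. Nothing measured here speaks to an aromatic group at that position, so the expectation rests on that one step alone. A modest rise beyond the scatter is therefore expected for compound 3, with the direction less certain than the size. For compound 3 the estimate in this assay is 200 mg/kg, within a range of 100 mg/kg to 600 mg/kg. That estimate corresponds to an expected step of a 2.0-fold higher number from compound 1 to compound 3 (0.30 log units; within the scatter).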

Compound 3, minimum effective dose: 300 mg/kg
Estimate against measurement, compound 3: 1.5-fold (0.18 log units) below; low and high end bracket the measured number.
By their numbers in this assay, from the lowest: compound 1; then compounds 2 and 3 (each within the scatter of the next).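

In this assay, placing the aromatic 4-nitrophenyl group on the amide-type nitrogen in a ring gives a 3.0-fold higher number from compound 1 to compound 3 (0.48 log units; beyond the scatter). This shows that the earlier rise seen with cyclohexyl is not unique to that group: a second ring group, this time aromatic, also gives a higher number than isopropyl. Replacing cyclohexyl with 4-nitrophenyl gives no change at the digits printed from compound 2 to compound 3 (within the scatter), so this assay does not separate the two ring groups at this position, and nothing available here offers a reason for the result.

The compounds shown leave open whether the nitro group contributes anything, a question that plain phenyl at the same nitrogen could address, and whether an amine or a carboxylic acid on that ring would shift the number. They also leave open what happens with groups other than rings and isopropyl, such as methyl or a longer chain like n-butyl, and so whether any group on this nitrogen can give a lower number than isopropyl does.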